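Swapping the Nitro for a Syringyl Pattern

The source may hold more compounds than are shown below. What is called first, only, known or untested is meant among the compounds shown, and "the series" means these compounds.

Measured compounds:
compound 1, `O=C(/C=C/c1ccc([N+](=O)[O-])cc1)Nc1cc2c(Nc3ccc(F)c(Cl)c3)ncnc2cc1O[C@H]1CCOC1` — 12000 nM
compound 2, `COc1ccc(/C=C/C(=O)Nc2cc3c(Nc4ccc(F)c(Cl)c4)ncnc3cc2O[C@H]2CCOC2)c(OC)c1` — 9350 nM
compound 3, `COc1cc(/C=C/C(=O)Nc2cc3c(Nc4ccc(F)c(Cl)c4)ncnc3cc2O[C@H]2CCOC2)cc(OC)c1OC` — 4150 nM

In a functional assay on A549 cells (Homo sapiens) for cytotoxicity, read by MTT assay, with a stated time of 72 h (a lower number here means a stronger inhibitor, a higher number a weaker inhibitor), compound 1 gives the highest of the three numbers, though compound 2 sits within the scatter of it. The step of a 1.3-fold lower number from compound 1 to compound 2 (0.11 log units; within the scatter) is therefore not meaningful on its own, whereas a 2.9-fold lower number from compound 1 to compound 3 (0.46 log units; beyond the scatter) is a modest but real gain, as is a 2.3-fold lower number from compound 2 to compound 3 (0.35 log units; beyond the scatter). Only compound 3 stands apart from compound 1 beyond the scatter.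

Compound 4, `COc1cc(/C=C/C(=O)Nc2cc3c(Nc4ccc(F)c(Cl)c4)ncnc3cc2O[C@H]2CCOC2)cc(OC)c1O`, is the unmeasured variant. Its change from compound 1 is 4-hydroxy-3,5-dimethoxyphenyl in place of 4-nitrophenyl on a double-bonded chain carbon bound to a double-bonded chain carbon. The group that enters shares its two methoxy groups with the 3,4,5-trimethoxyphenyl of compound 3 and differs from it only in a hydroxy in place of the third methoxy. Within the data shown here, the step of a 2.9-fold lower number from compound 1 to compound 3 (0.46 log units; beyond the scatter) is the closest precedent; the step of a 1.3-fold lower number from compound 1 to compound 2 (0.11 log units; within the scatter) shows that a methoxy pattern alone does not guarantee a shift beyond the scatter. Compound 4 is accordingly expected to land near compound 3, with a step of a 2.7-fold lower number from compound 1 to compound 4 (0.43 log units; beyond the scatter) in the direction of a lower number.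

Compound 4 is estimated at 4500 nM, within a range of 2000 nM to 10000 nM.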

Compound 4, half-maximal inhibitory concentration: 27000 nM
Compound 4: middle estimate off by 6.0-fold (0.78 log units), on the low side; measured number above the stated range.
By their numbers in this assay, from the lowest: compound 3; then compounds 2 and 1 (each within the scatter of the next); then compound 4.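

In this assay the smallest change in the series is also the most telling: hydrogen in place of methyl on an oxygen on an aromatic ring gives a 6.5-fold higher number from compound 3 to compound 4 (0.81 log units; beyond the scatter) and so separates the lowest number of the four from the highest. Among these compounds, until this result, each replacement of the 4-nitrophenyl had either lowered the number or stayed within the scatter, but the 4-hydroxy-3,5-dimethoxyphenyl group raises it, with a 2.3-fold higher number from compound 1 to compound 4 (0.35 log units; beyond the scatter) and a 2.9-fold higher number from compound 2 to compound 4 (0.46 log units; beyond the scatter) as its two steps at this place. The two methoxy groups shared by compound 3 and compound 4 are therefore not enough to set the outcome, since these two compounds fall on opposite sides of compound 1, and a single methyl decides the direction.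

From the compounds shown here alone, whether the rise belongs to the free hydroxy itself, or would also appear with an ethoxy on that oxygen or with an amine or a fluorine in its place, remains open. Nothing measured on these compounds bears on why the number rises, so the result stands without an explanation.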